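Same Ester Swap Tested on a Second Core

The compounds below may be only part of what the source reports. "The series", "measured", "known", "first", "only" and "open" are said of these compounds alone.

Compound 1 `CC1=C(C(=O)OC(C)(C)C)C(c2ccoc2)NC(=O)N1`: 2%
Compound 2 `CC1=C(C(=O)OCc2ccccc2)C(c2ccoc2)NC(=O)N1`: 1%
Compound 3 `CC1=C(C(=O)OC(C)(C)C)C(c2ccco2)NC(=O)N1C`: 54%

All three were measured in an assay on membranes from HeLa cells for displacement of a labelled ligand from adenosine receptor A3 (Homo sapiens), read by scintillation counting, with a stated time of 180 min, tested at 1 uM; on this read-out lower numbers stand for less inhibition and higher numbers for more inhibition at the one concentration tested (going by the name of the read-out). Compound 1 and compound 2 share one core and differ by a single change, (benzyl in place of tert-butyl on an oxygen next to a carbonyl group). That change made a number 1 percentage points lower from compound 1 to compound 2 (within the scatter). Compound 3 carries a different core; the difference between the two cores is not broken down here. In this assay compound 3 gives 54%, the highest of the three numbers, and its gaps to compound 1 and compound 2 lie beyond the scatter.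

Compound 4 `CC1=C(C(=O)OCc2ccccc2)C(c2ccco2)NC(=O)N1C` has not yet been measured. It is compound 3 with the same change made on it, (benzyl in place of tert-butyl on an oxygen next to a carbonyl group), at the same place as before. Among the measured compounds shown here, since the only earlier example of this change, a number 1 percentage points lower from compound 1 to compound 2 (within the scatter), stayed within the scatter, the step from compound 3 to compound 4 is expected to be small as well, a number 4 percentage points lower from compound 3 to compound 4 (within the scatter), though the earlier pair sat low in the read-out and its behaviour need not carry over to a core that reads higher. On that basis compound 4 is estimated at 50%, with a likely range from 30% to 68%.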

Compound 4, a percentage reported as inhibition, at one concentration (the size of the read-out at that concentration, not a potency): 11%
Compound 4: middle estimate off by 39 percentage points, on the high side, and the stated range ends above it.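

Benzyl in place of tert-butyl on an oxygen next to a carbonyl group does not behave alike on the two cores in this assay, where this change gives a number 43 percentage points lower from compound 3 to compound 4 (beyond the scatter). Set beside the earlier pair, the two steps clearly disagree: the same change on two cores in this assay, a number 1 percentage points lower (within the scatter) from compound 1 to compound 2 and a number 43 percentage points lower (beyond the scatter) from compound 3 to compound 4, 42 percentage points apart, beyond the scatter of two such steps

So the near-silent step on the core of compound 1 was no guide to the core of compound 3, although two pairs cannot show which feature of the core decides the outcome, and compound 1 starts at only 2%, which leaves that pair little room to fall. The cores of compound 1 and compound 3 differ in more than one place, and no pair shown separates those differences. Also open, on these data alone, is how an ethyl or a cyclohexyl group on that oxygen would read on the core of compound 3, which would show whether the drop is specific to benzyl or follows any replacement of tert-butyl.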